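This account rests on a few compounds, and the source may have more. Where it says the series, first, only, none or still open, it means among the compounds named here.

Measured in a physicochemical assay for solubility, in phosphate buffer, measured as kinetic solubility, at pH 7.4, tested at 250 uM (a higher number here means a more soluble compound, a lower number a less soluble compound), so far
Compound 1 `CCCCCCNc1ccc([N+](=O)[O-])cc1S(N)(=O)=O` gives 6000 nM
Compound 2 `CCCCCCNc1ccc([N+](=O)[O-])cc1S(=O)(=O)N(C)C` gives 1000 nM
Compound 3 `CCCCCCCCNc1ccc(C(=O)O)cc1S(=O)(=O)NC` gives 53000 nM

Compound 2 has the lowest number of these three. Compound 4 `CCCCCCNc1ccc(C(=O)O)cc1S(=O)(=O)N(C)C`, not yet measured, differs from it by carboxy in place of nitro on an aromatic carbon and the rest stays the same. Going by the values given here, the one measured step, a 6.0-fold lower number from compound 1 to compound 2 (0.78 log units; beyond the scatter), is dimethylamino in place of amino on a sulfonyl sulfur, a change in another place, so it gives no direct guide. Compound 3 also carries carboxy and gives 53000 nM, though its chain and sulfonyl group differ as well, so a higher number than for compound 2 is expected in this assay on this single value. The expected step is a 50-fold higher number from compound 2 to compound 4 (1.70 log units; beyond the scatter), beyond the scatter. For compound 4 the estimate is 50000 nM, with an expected range from 12000 nM to 200000 nM.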

Compound 4, solubility: 243000 nM
Compound 4: the middle estimate sits 4.9-fold (0.69 log units) below what was measured; the measured number lies above the stated range.
By their numbers in this assay, from the lowest: compound 2; then compound 1; then compound 3; then compound 4.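

In this assay, carboxy in place of nitro, on the aromatic carbon para to a hexylamino group and meta to a dimethylsulfamoyl group, gives a 240-fold higher number from compound 2 to compound 4 (2.39 log units; beyond the scatter). This shows that this position, unchanged between compound 1 and compound 2, can shift the number by a large step while the rest of the compound stays the same. Nothing measured here gives a reason for the step. From the compounds shown here alone, whether a primary amide or a nitrile at this position would give a similar number remains open, as does whether carboxy would give a step of this size with the amino group of compound 1 on the sulfonyl sulfur.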